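Arylhydrazone series: naphthyl group replacing the fluorohydroxyphenyl

A few compounds are considered here, and "the series" means these few. Any claim that something is new, unique, unknown or untested is made for them only; others in the source may bear on it.

Compound 1 `CN(C)CCn1cnnc1-c1cc(Oc2ccc(NC(=O)N/N=C/c3cccc(Br)c3)cc2F)ccn1` gives 450 nM in a functional assay on MKN-45 cells (Homo sapiens) for cytotoxicity, read by MTT assay, with a stated time of 72 h; a lower number here means a stronger inhibitor, a higher number a weaker inhibitor. Compound 2 `CN(C)CCn1cnnc1-c1cc(Oc2ccc(NC(=O)N/N=C/c3cccc(O)c3)cc2F)ccn1` gives 1370 nM, and compound 3 `CN(C)CCn1cnnc1-c1cc(Oc2ccc(NC(=O)N/N=C/c3ccc(O)c(F)c3)cc2F)ccn1` gives 1970 nM, the highest of the three numbers, with compound 2 nearest and compound 1 furthest. The measured steps are a 3.0-fold higher number from compound 1 to compound 2 (0.48 log units; beyond the scatter) and a 4.4-fold higher number from compound 1 to compound 3 (0.64 log units; beyond the scatter), both modest and beyond the scatter, while a 1.4-fold higher number from compound 2 to compound 3 (0.16 log units; within the scatter) stays within it. Compound 4 `CN(C)CCn1cnnc1-c1cc(Oc2ccc(NC(=O)N/N=C/c3c(O)ccc4ccccc34)cc2F)ccn1` carries 2-hydroxynaphthalen-1-yl in place of 3-fluoro-4-hydroxyphenyl on a carbon with a double bond to nitrogen. Within the data shown here, no measured step bears directly on this change; the steps seen so far only show that swapping the aryl group shifts the number modestly where it shifts at all. For compound 4 a step of a 1.6-fold lower number from compound 3 to compound 4 (0.22 log units; within the scatter) is expected in this assay, held with low confidence. Compound 4 is therefore estimated at 1200 nM, with a range from 400 nM to 3600 nM.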

Compound 4, half-maximal inhibitory concentration: 2020 nM
Compound 4: middle estimate off by 1.7-fold (0.23 log units), on the low side; measured number inside the range.
By their numbers in this assay, from the lowest: compound 1; then compounds 2, 3 and 4 (each within the scatter of the next).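

On the carbon with a double bond to nitrogen, 2-hydroxynaphthalen-1-yl reads level with 3-fluoro-4-hydroxyphenyl in this assay (a 1.0-fold higher number from compound 3 to compound 4 (0.01 log units; within the scatter)) and with 3-hydroxyphenyl (a 1.5-fold higher number from compound 2 to compound 4 (0.17 log units; within the scatter)), so a second aromatic ring leaves the number within the scatter of the single-ring hydroxy compounds. Compound 1, with 3-bromophenyl and no hydroxy, remains apart (a 4.5-fold higher number from compound 1 to compound 4 (0.65 log units; beyond the scatter)), and none of the four compounds goes against this split. No measured evidence accounts for these numbers. Open, on these data alone, is whether a bromo-bearing naphthalenyl group would match compound 1, and whether an amine or a carboxylic acid on the aryl group would read apart from the hydroxy compounds.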